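Chloro Substitution on the Benzoyl Group in Two Related Series

The source may report more compounds than this note shows. Statements on the series, on what has been measured and on what is new or still open speak of the compounds shown alone.

Compound 2, `O=C(Nc1ccccc1O)C1CCc2ccccc2N1C(=O)c1ccccc1`, serves as the reference of the first pair. In a functional assay on HCT-15 cells (Homo sapiens) for cytotoxicity, read by sulforhodamine B assay, with a stated time of 72 h (a lower number here means a stronger inhibitor of growth, a higher number a weaker inhibitor of growth), compound 2 gives 3830 nM. Compound 1, `O=C(Nc1ccccc1O)C1CCc2ccccc2N1C(=O)c1ccccc1Cl`, carries chloro in place of hydrogen on an aromatic carbon. In this assay compound 1 gives 44900 nM, and the step of a 12-fold higher number from compound 2 to compound 1 (1.07 log units; beyond the scatter) is a clear weakening of growth inhibition.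

Compound 3, `O=C(Nc1cc(C(F)(F)F)cc(C(F)(F)F)c1)C1CCc2ccccc2N1C(=O)c1ccccc1`, opens a second pair; the difference between its core and the core of compound 2 is not broken down here. In this assay compound 3 gives 3540 nM, a number within the scatter of the value of compound 2.

Compound 4, `O=C(Nc1cc(C(F)(F)F)cc(C(F)(F)F)c1)C1CCc2ccccc2N1C(=O)c1cccc(Cl)c1`, has not yet been measured. It differs from compound 3 by chloro in place of hydrogen on an aromatic carbon. Among the measured compounds shown here, this is the same kind of change as the one from compound 2 to compound 1, but not the same change: in compound 1 the chloro sits ortho to a large group, whereas in compound 4 it sits meta to a large group.

For the measured compounds named here, the only measured instance of this kind of change, a 12-fold higher number from compound 2 to compound 1 (1.07 log units; beyond the scatter), was a large rise. Compound 4 is therefore expected to give a higher number than compound 3, and the expected step of a 2.5-fold higher number from compound 3 to compound 4 (0.41 log units; beyond the scatter) is set smaller than the measured one, since the place of the chloro differs and the cores are not the same. Compound 4 is estimated at 9000 nM, with a range from 2500 nM to 35000 nM.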

Compound 4, concentration for 50% growth inhibition: 625 nM
Compound 4: the middle estimate sits 14-fold (1.16 log units) above what was measured, and the stated range ends above it.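

In this assay, chloro in place of hydrogen on an aromatic carbon moved the number in the opposite direction on the second core, with a 5.7-fold lower number from compound 3 to compound 4 (0.75 log units; beyond the scatter) as benzoyl became (3-chlorophenyl)carbonyl, so the same kind of change that weakened growth inhibition on the core of compound 2 strengthened it on the core of compound 3, and the two steps lie further apart than their scatter allows: the same change on two cores in this assay, a 12-fold higher number (1.07 log units; beyond the scatter) from compound 2 to compound 1 and a 5.7-fold lower number (0.75 log units; beyond the scatter) from compound 3 to compound 4, 66-fold (1.82 log units) apart, beyond the scatter of two such steps. In this series, then, the step measured on one core gave no reliable guide to either the direction or the size of the step on the other. Among the compounds shown here, it does not show what separates the two results, since the chloro differs in place as well as in core between compound 1 and compound 4, and each core offers only a single pair, so neither the place nor the core can be singled out.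

The compounds shown leave open how a chloro at one and the same place would behave on both cores, which would separate these two differences. They also leave open whether a different group at the place of the chloro, such as a methoxy group, a nitrile or an amine, would follow the chloro on either core.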